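The source may hold more compounds than are shown below. What is called first, only, known or untested is meant among the compounds shown, and "the series" means these compounds.

Three compounds have numbers in an assay on HEK293 cells for inhibition of SCN8A/SCN1B (Homo sapiens), read by patch clamp, with a stated time of 20 min; a higher number here means a weaker inhibitor, a lower number a stronger inhibitor. Compound 1 `CC(c1ccccc1)N1CCc2cc(S(=O)(=O)Nc3nccs3)ccc21` gives 860 nM. Compound 2 `CCC(Nc1ccc(S(=O)(=O)Nc2nccs2)cc1Cl)c1ccccc1` gives 50 nM, the lowest of the three. Compound 3 `CCC(c1ccccc1)N(C)c1ccc(S(=O)(=O)Nc2nccs2)cc1Cl` gives 1410 nM. Within the data shown here, the one single-point step among them runs a 28-fold higher number from compound 2 to compound 3 (1.45 log units; beyond the scatter), so replacing the hydrogen on the ring nitrogen of compound 2 with a methyl weakens inhibition sharply. Among the measured compounds shown here, compound 1 differs from compound 2 in more than one place, so its gap to compound 2 shows only that compound 2 is the stronger of the pair.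

Compound 4 `CC(Nc1ccc(S(=O)(=O)Nc2nccs2)cc1Cl)c1ccccc1` is not yet measured. Relative to compound 2 it carries hydrogen in place of methyl on a saturated chain carbon, two bonds along the chain from an aromatic carbon and a nitrogen on an aromatic ring. This change sits on the chain carbon, not on the ring nitrogen, so the step from compound 2 to compound 3 does not bear on it directly; it only warns that this part of the molecule is sensitive. For the measured compounds named here, no measured pair varies the chain length here, so there is no precedent to lean on. Trimming one carbon from the chain is expected to shift this assay little, perhaps toward a slightly higher number. The expected step is a 1.8-fold higher number from compound 2 to compound 4 (0.26 log units; within the scatter). Compound 4 is therefore estimated at 90 nM, within a range from 35 nM to 250 nM.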

Compound 4, half-maximal inhibitory concentration: 100 nM
The estimate for compound 4 lay 1.1-fold (0.05 log units) below the measured number; low and high end bracket the measured number.
By their numbers in this assay, from the lowest: compounds 2 and 4 (each within the scatter of the next); then compounds 1 and 3 (each within the scatter of the next).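

In this assay, going from ethyl to methyl on the saturated chain carbon gives a 2.0-fold higher number from compound 2 to compound 4 (0.30 log units; within the scatter) and so does not separate the two compounds. Among these compounds, the only earlier single-place change was on the ring nitrogen, where methyl in place of hydrogen gave a 28-fold higher number from compound 2 to compound 3 (1.45 log units; beyond the scatter) and weakened inhibition sharply, whereas this first change at the chain carbon shows no such loss, so a large effect at the nitrogen does not carry over to this nearby position. Nothing available here explains why the two positions respond so differently.

The compounds shown cover only ethyl and methyl on this chain carbon, so it remains open whether a longer chain such as propyl, or a ring such as cyclopropyl, would leave the number unchanged or move it beyond the scatter. From the compounds shown here alone, it also remains open how a hydroxyl or an amine at the end of this chain would read in this assay, and whether any group other than methyl on the ring nitrogen would bring the same sharp loss.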